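Replacing the thiazoline sulfur arm by a methylpiperazine

The source may report more compounds than this note shows. Statements on the series, on what has been measured and on what is new or still open speak of the compounds shown alone.

Measured so far in a functional assay on MCF7 cells (Homo sapiens) for cytotoxicity, read by MTT assay, with a stated time of 24 h, tested at 32 ug/mL; on this read-out higher numbers stand for a stronger effect at the one concentration tested and lower numbers for a weaker effect:
Compound 1 `Cn1c(-c2ccc(NC(=O)CSc3nc4ccccc4s3)cc2)nc(-c2ccccc2)c1-c1ccccc1` gives 59%
Compound 2 `Cc1nnc(SCC(=O)Nc2ccc(-c3nc(-c4ccccc4)c(-c4ccccc4)n3C)cc2)s1` gives 83.4%
Compound 3 `Cn1c(-c2ccc(NC(=O)CSC3=NCCS3)cc2)nc(-c2ccccc2)c1-c1ccccc1` gives 52.5%

Compound 3 stands lowest of the three numbers shown, but its nearest neighbour is compound 1, and the step of a number 6.5 percentage points lower from compound 1 to compound 3 (within the scatter) lies within the scatter, so the two cannot be ordered. Only compound 2 is clearly apart: the step of a number 30.9 percentage points lower from compound 2 to compound 3 (beyond the scatter) is large, as is, in the other direction, a number 24.4 percentage points higher from compound 1 to compound 2 (beyond the scatter).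

Compound 4 `CN1CCN(CC(=O)Nc2ccc(-c3nc(-c4ccccc4)c(-c4ccccc4)n3C)cc2)CC1` is the next compound. It differs from compound 3 by a group of 7 heavy atoms (5 carbon, 2 nitrogen; one six-membered non-aromatic ring with 2 hetero atoms) in place of a group of 6 heavy atoms (3 carbon, 1 nitrogen, 2 sulfur; one five-membered non-aromatic ring with 2 hetero atoms), on a saturated chain carbon bound to a carbonyl carbon. All three measured steps exchange the group that sits on the sulfur, whereas this change removes the sulfur together with its ring and puts a nitrogen-linked ring in its place. Going by the values given here, no measured step therefore bears directly on it; the measured steps only show that changes in this region of the core have ranged from within the scatter to large.

With that in mind, compound 4 is expected to remain near compound 3, with the step of a number 2.5 percentage points lower from compound 3 to compound 4 (within the scatter) estimated as small and uncertain. The estimated value for compound 4 in this assay is 50%, within a range from 25% to 78%.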

Compound 4, a percentage reported as activity, at one concentration (the size of the read-out at that concentration, not a potency): 46.2%
Estimate against measurement, compound 4: 3.8 percentage points above; measured number inside the range.
By their numbers in this assay, from the lowest: compounds 4, 3 and 1 (each within the scatter of the next, the first and the last beyond it); then compound 2.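

Going by these compounds alone, compound 4 is the first compound here in which the sulfur is gone from the saturated chain carbon bound to a carbonyl carbon, and in this assay the entry of 4-methylpiperazin-1-yl at that place gives no separable change against the sulfur-linked non-aromatic ring (a number 6.3 percentage points lower from compound 3 to compound 4 (within the scatter)). The same group does separate from both sulfur-linked aromatic groups, with a modest drop when it replaces (1,3-benzothiazol-2-yl)sulfanyl (a number 12.8 percentage points lower from compound 1 to compound 4 (beyond the scatter)) and a large one when it replaces (5-methyl-1,3,4-thiadiazol-2-yl)sulfanyl (a number 37.2 percentage points lower from compound 2 to compound 4 (beyond the scatter)), the largest step in the set. The information given offers no explanation for these differences.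

Going by these compounds, it remains open whether the reading of compound 4 belongs to the piperazine ring, to its methyl group or to the loss of the sulfur, which a plain piperazine, a morpholine or an open-chain dimethylamino group at the same place could help separate. On these data alone, it is also open whether 5-methyl-1,3,4-thiadiazol-2-yl keeps its high reading when attached to the chain through an oxygen or an amine nitrogen instead of sulfur.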